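This account rests on a few compounds, and the source may have more. Where it says the series, first, only, none or still open, it means among the compounds named here.

Compounds measured so far:
- compound 1, `COc1ccc(-c2c(C)nc3c(N4CC[C@@H](NS(=O)(=O)C(C)C)C4)cc(C)nn23)cc1OC`: in an ADME assay on microsomes from liver (Mus musculus) for metabolic stability, read by LC-MS, with NADPH named in the record, with a stated time of 60 min, tested at 1 uM, in the absence of a further agent (a lower number here means that less of the compound is left, a higher number that more of the compound is left), compound 1 gives > 95%, which is a limit of the assay and not a number.
- compound 2, `COc1ccc(-c2c(C)nc3c(N4CC[C@@H](NS(=O)(=O)c5ccc(C(C)=O)cc5)C4)cc(C)nn23)cc1OC`: in this assay compound 2 gives > 95%, again a limit rather than a number.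

Within the data shown here, compound 1 therefore stands only at a limit in this assay, and the one further value shown, that of compound 2, is also a limit. Among the measured compounds shown here, the single measured step, a step that the two limits leave unreadable from compound 1 to compound 2, is a change of 4-acetylphenyl in place of isopropyl on a sulfonyl sulfur, and its size cannot be read because of the limit of > 95% in this assay, at which 2 of the 2 values shown sit.

Compound 3, `COc1ccc(-c2c(C)nc3c(N4CC[C@@H](n5cc(-c6ccccc6)nn5)C4)cc(C)nn23)cc1OC`, is not yet measured. It differs from compound 1 by 4-phenyl-1H-1,2,3-triazol-1-yl in place of (isopropylsulfonyl)amino on a saturated ring carbon. For the measured compounds named here, no measured step bears directly on this change: the step from compound 1 to compound 2 altered the group on the sulfonyl sulfur and left the sulfonamide in place, whereas here the whole (isopropylsulfonyl)amino group leaves and 4-phenyl-1H-1,2,3-triazol-1-yl enters on the saturated ring carbon. With both shown values at the limit, no size or direction of step can be read from the data. Compound 3 is expected to remain mostly intact, at about 80%, within 50% to 97%. The step from compound 1 to compound 3 that this estimate means, a number at least 15 percentage points lower from compound 1 to compound 3 (beyond the scatter), is an expectation only, and a result at the limit is thought likely.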

Compound 3, percent of the compound remaining: "unstable" (no number reported)
No number was reported for compound 3; no gap can be computed for the estimate.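

No step from compound 1 to compound 3 can be read in this assay, since compound 3 has a verbal result and no number, and compound 1 stands at a limit of the assay: the limit of > 95% in this assay, at which 2 of the 3 values shown sit.

The compounds shown leave open how much of compound 3 remains, and so how large the change is when 4-phenyl-1H-1,2,3-triazol-1-yl replaces (isopropylsulfonyl)amino.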